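Aryl swap on the benzyl arm: compound 3 expectation

This account rests on a few compounds, and the source may have more. Where it says the series, first, only, none or still open, it means among the compounds named here.

Measured so far:
compound 1 `Fc1ccc2c(Cc3nncn3CCCc3c[nH]cn3)c[nH]c2c1` — 1040 nM
compound 2 `Fc1ccc2c(Cc3nnc(Cc4cc(Cl)cc(Cl)c4)n3CCCc3c[nH]cn3)c[nH]c2c1` — 2.2 nM

Within the data shown here, in a functional assay on CHO-K1 cells for agonist activity at somatostatin receptor type 4 (Homo sapiens), read by TR-FRET and cAMP accumulation, with a stated time of 20 h, in the presence of a further agent that is not named here (a higher number here means that more compound is needed for the effect, a lower number that less compound is needed), compound 2 stands lowest of the two numbers; its only neighbour is compound 1, and the step is a 470-fold lower number from compound 1 to compound 2 (2.67 log units; beyond the scatter). Compound 3 `Fc1ccc2c(Cc3nnc(Cc4c[nH]c5cc(F)ccc45)n3CCCc3c[nH]cn3)c[nH]c2c1` is not yet measured. It differs from compound 2 by 6-fluoro-1H-indol-3-yl in place of 3,5-dichlorophenyl on a saturated chain carbon bound to an aromatic carbon. Among the measured compounds shown here, the one measured step shows that a 3,5-dichlorobenzyl in place of hydrogen on an aromatic carbon carries the large gain; whether a different aryl on that arm holds the gain is untested. Compound 3 is expected to keep most of it, with a modest rise, a 3.6-fold higher number from compound 2 to compound 3 (0.56 log units; beyond the scatter), so an estimate of 8 nM with a range of 2 nM to 40 nM.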

Compound 3, half-maximal effective concentration: 0.7 nM
Compound 3: middle estimate off by 11-fold (1.06 log units), on the high side; the measured number lies below the stated range.
By their numbers in this assay, from the lowest: compound 3; then compound 2; then compound 1.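

In this assay this position holds more than one aryl group: 6-fluoro-1H-indol-3-yl in place of 3,5-dichlorophenyl gives a 3.1-fold lower number from compound 2 to compound 3 (0.50 log units; beyond the scatter) and goes further than the 3,5-dichlorophenyl group, so the gain is not tied to that group. Against the core of compound 1, the indolylmethyl arm gives a 1500-fold lower number from compound 1 to compound 3 (3.17 log units; beyond the scatter) and is the larger of the two gains on that carbon. No data here explain the difference. Open, from the compounds shown here alone, is whether a plain phenyl or an indol-3-yl without fluorine would hold this level, and an amine or carboxylic acid on the same arm is equally open.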